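Cyano in place of sulfamoyl in compound 1

This account rests on a few compounds, and the source may have more. Where it says the series, first, only, none or still open, it means among the compounds named here.

compound 1 `Cc1cc(Nc2cc(N3CCN(C)CC3)nc(Nc3ccc(S(N)(=O)=O)cc3)n2)n[nH]1` gives 926 nM
compound 2 `Cc1cc(Nc2cc(N3CCN(C)CC3)nc(Nc3cccc(Cl)c3)n2)n[nH]1` gives 3090 nM

In a functional assay on DU-145 cells (Homo sapiens) for antiproliferative activity, read by CCK-8 assay, with a stated time of 72 h (a higher number here means a weaker inhibitor, a lower number a stronger inhibitor), compound 1 holds the lower of the two numbers, making it the stronger of this pair. Compound 3 `Cc1cc(Nc2cc(N3CCN(C)CC3)nc(Nc3ccc(C#N)cc3)n2)n[nH]1` differs from it in one group cyano in place of sulfamoyl on an aromatic carbon with cyano in place of sulfamoyl on an aromatic carbon. Within the data shown here, one measured step bears on this, a modest one in which sulfamoyl also leaves: a 3.3-fold higher number from compound 1 to compound 2 (0.52 log units; beyond the scatter) with 3-chlorophenyl in place of 4-sulfamoylphenyl. A step of similar size toward a higher number is therefore expected in this assay as an estimated 2.1-fold higher number from compound 1 to compound 3 (0.31 log units; beyond the scatter) and no more than that. The expected value for compound 3 is 1900 nM with 700 nM to 5000 nM as its estimated range.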

Compound 3, half-maximal inhibitory concentration: 1270 nM
Beside the measured number, compound 3's estimate is 1.5-fold (0.17 log units) above it; low and high end bracket the measured number.
By their numbers in this assay, from the lowest: compounds 1 and 3 (each within the scatter of the next); then compound 2.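

In this assay, the sulfamoyl group can give way to cyano on this aromatic carbon with no change beyond the scatter: a 1.4-fold higher number from compound 1 to compound 3 (0.14 log units; within the scatter). The step of a 2.4-fold lower number from compound 2 to compound 3 (0.39 log units; beyond the scatter) shows that losing sulfamoyl does not by itself account for the weaker number of compound 2, since 4-cyanophenyl also lacks it. No evidence here speaks to what lies behind either step. As far as these compounds go, it remains open whether a carboxylic acid or an amine would fare as cyano does on this carbon, and whether 4-chlorophenyl would track 4-cyanophenyl or 3-chlorophenyl.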